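The source may report more compounds than this note shows. Statements on the series, on what has been measured and on what is new or still open speak of the compounds shown alone.

Compound 1 `O=C(C1CCC1)N1CCc2nc(C#Cc3ccccc3)sc2C1`: in an assay on HEK293 cells for positive allosteric modulation of metabotropic glutamate receptor 5 (Homo sapiens), read by FLIPR, with a stated time of 1 h (on this read-out lower numbers stand for an effect already at smaller amounts and higher numbers for an effect only at larger amounts of compound), compound 1 gives > 10000 nM, which is a limit of the assay rather than a number.
Compound 2 `O=C(CC1CCOCC1)N1CCc2nc(C#Cc3ccccc3)sc2C1`: in this assay compound 2 gives 470 nM.

Compound 1 thus sits at the limit of > 10000 nM in this assay, at which 1 of the 2 values shown sits, so only a limit is known for it. Compound 3 `CC(C)S(=O)(=O)N1CCc2nc(C#Cc3ccccc3)sc2C1` differs from compound 1 by isopropylsulfonyl in place of cyclobutylcarbonyl on an amine nitrogen in a ring. Among the measured compounds shown here, the one measured step, an at least 21-fold lower number from compound 1 to compound 2 (1.32 log units; beyond the scatter), shows that the group on this nitrogen can move the number far, but it concerns a different group and does not touch a sulfonyl. For the measured compounds named here, no measured step bears directly on compound 3, so its direction is open. Compound 3 is nevertheless expected to remain weak, an at least 2.0-fold lower number from compound 1 to compound 3 (0.30 log units; that floor lies within the scatter). Compound 3 is estimated at 5000 nM, within 800 nM to 30000 nM.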

Compound 3, half-maximal effective concentration: > 10000 nM
Compound 3 gave a limit, no number; the forecaster's own chance of this, stated with the estimate: 50%; at least 2.0-fold (0.30 log units) between middle value and limit.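

Among the compounds shown here, compound 1 and compound 3 both stand at the same limit of the assay, so no step between them can be read: the limit of > 10000 nM in this assay, at which 2 of the 3 values shown sit.

The compounds shown leave open how isopropylsulfonyl compares with cyclobutylcarbonyl on this nitrogen.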